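A few compounds are considered here, and "the series" means these few. Any claim that something is new, unique, unknown or untested is made for them only; others in the source may bear on it.

Measured so far:

Compound 1, `CC(=O)C[C@H]1O[C@@H](On2cc(CN3C(=O)/C(=N\Nc4ccccc4)c4ccccc43)nn2)[C@H](OC(C)=O)[C@@H](OC(C)=O)[C@H]1OC(C)=O`, gives 65200 nM in an ADME assay on Vero cells (Chlorocebus sabaeus) for cytotoxicity, read by fluorescence and resazurin assay, with a stated time of 3 days; a lower number here means that less compound is tolerated, a higher number that more compound is tolerated.
Compound 2, `CC(=O)C[C@H]1O[C@@H](On2cc(CN3C(=O)/C(=N\Nc4ccc(Br)cc4)c4ccccc43)nn2)[C@H](OC(C)=O)[C@@H](OC(C)=O)[C@H]1OC(C)=O`, gives 83400 nM in this assay.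
Compound 3, `CC1(C)O[C@H]2O[C@H](Cn3cc(CN4C(=O)/C(=N\Nc5ccccc5)c5ccccc54)nn3)[C@H](O)[C@H]2O1`, gives 82100 nM in this assay.

Compound 4, `CC1(C)O[C@H]2O[C@H](Cn3cc(CN4C(=O)/C(=N\Nc5ccc(Br)cc5)c5ccccc54)nn3)[C@H](O)[C@H]2O1`, has not yet been measured. It differs from compound 3 by bromo in place of hydrogen on an aromatic carbon. The same change separates compound 1 from compound 2, namely (bromo in place of hydrogen on an aromatic carbon), and there it made the step of a 1.3-fold higher number from compound 1 to compound 2 (0.11 log units; within the scatter). The difference between the core of compound 1 and the core of compound 3 is not broken down here. The two values of compound 2 and compound 3 lie close together.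

Because the step of a 1.3-fold higher number from compound 1 to compound 2 (0.11 log units; within the scatter) was small, the step from compound 3 to compound 4 in this assay is expected to be a 1.2-fold higher number from compound 3 to compound 4 (0.09 log units; within the scatter). For compound 4 the expected value in this assay is 100000 nM, with a range from 50000 nM to 200000 nM.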

Compound 4, half-maximal cytotoxic concentration: 72900 nM
Estimate against measurement, compound 4: 1.4-fold (0.14 log units) above; low and high end bracket the measured number.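

In this assay, the change from phenyl to 4-bromophenyl gives a 1.1-fold lower number from compound 3 to compound 4 (0.05 log units; within the scatter), and the two steps for this change agree: the same change on two cores in this assay, a 1.3-fold higher number (0.11 log units; within the scatter) from compound 1 to compound 2 and a 1.1-fold lower number (0.05 log units; within the scatter) from compound 3 to compound 4, 1.4-fold (0.16 log units) apart, within the scatter of two such steps

On these two cores, then, the change carries over in the sense that neither step can be told apart from repeat-to-repeat scatter. This does not show that bromo would be equally without effect on a third core or in a different kind of test, since two pairs are a small sample.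

What the compounds shown leave open is whether another group in place of the bromo, such as an amine or a carboxylic acid, would give a step beyond the scatter.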